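The source may report more compounds than this note shows. Statements on the series, on what has been measured and on what is new or still open speak of the compounds shown alone.

In an ADME assay on THP-1 cells (Homo sapiens) for cytotoxicity, read by flow cytometry and propidium iodide staining, with a stated time of 72 h (on this read-out higher numbers stand for weaker inhibition and lower numbers for stronger inhibition), the measured compounds read:
Compound 1 `CC(=O)Nc1ccc2oc(-c3cccc(C(F)(F)F)c3)c(O)c(=O)c2c1` gives 1000 nM as a number
Compound 2 `COc1c(-c2ccccc2)oc2ccc(NC(C)=O)cc2c1=O` gives > 125000 nM as a limit
Compound 3 `COc1c(-c2ccc(F)cc2)oc2ccc(NC(C)=O)cc2c1=O` gives > 125000 nM as a limit

Compound 2 stands at the limit of > 125000 nM in this assay, at which 2 of the 3 values shown sit, and so has a limit, not a number. Compound 4 `COc1c(-c2cccc(C(F)(F)F)c2)oc2ccc(NC(C)=O)cc2c1=O` has trifluoromethyl in place of hydrogen on an aromatic carbon and no other change. The closest measured step, a step that the two limits leave unreadable from compound 2 to compound 3, gives no size to carry over. Compound 1 also carries trifluoromethyl and gives 1000 nM on a core that differs, which is only a weak hint toward stronger inhibition. No firm step beyond the scatter is therefore expected, only a slight lean toward lower numbers. The expected change is an at least 1.2-fold lower number from compound 2 to compound 4 (0.09 log units; that floor lies within the scatter) in this assay and may be hidden by the limit. Compound 4 is estimated at 100000 nM, with an expected range from 25000 nM to 250000 nM and a good chance of only a limit.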

Compound 4, half-maximal inhibitory concentration: 52000 nM
Beside the measured number, compound 4's estimate is 1.9-fold (0.28 log units) above it, and the stated range covers the measured number.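

In this assay, trifluoromethyl at this position gives the first step among these compounds with a readable direction: an at least 2.4-fold lower number from compound 2 to compound 4 (0.38 log units; beyond the scatter). That size is only a minimum, because compound 2 has a limit and not a number: the limit of > 125000 nM in this assay, at which 2 of the 4 values shown sit. With trifluoromethyl kept, methyl in place of hydrogen on the oxygen gives a 52-fold higher number from compound 1 to compound 4 (1.72 log units; beyond the scatter), so trifluoromethyl alone does not bring compound 4 close to compound 1. As far as these compounds go, whether an amine or a carboxylic acid at this position would shift the number in the same direction remains open. So does the effect of a longer chain on that oxygen.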